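A Pyrimidine Swap Tested on Two Related Cores

This account rests on a few compounds, and the source may have more. Where it says the series, first, only, none or still open, it means among the compounds named here.

Compound 1 `O=C(CSC(=S)N1CCN(c2ccccc2)CC1)Nc1cccc(NC(=O)c2ccccn2)c1` and compound 2 `O=C(CSC(=S)N1CCN(c2ncccn2)CC1)Nc1cccc(NC(=O)c2ccccn2)c1` share one core, while compound 3 `O=C(CCSC(=S)N1CCN(c2ccccc2)CC1)Nc1cccc(NC(=O)c2ccccn2)c1` and compound 4 `O=C(CCSC(=S)N1CCN(c2ncccn2)CC1)Nc1cccc(NC(=O)c2ccccn2)c1` share another, and the difference between the two cores is not broken down here. In a functional assay on A549 cells (Homo sapiens) for antiproliferative activity, read by MTT assay, with a stated time of 48 h (on this read-out lower numbers stand for stronger inhibition and higher numbers for weaker inhibition), compound 1 gives 530 nM, compound 2 gives 40 nM, and compound 3 gives 31700 nM. Compound 2 differs from compound 1 by pyrimidin-2-yl in place of phenyl on an amine nitrogen in a ring, and this change made a 13-fold lower number from compound 1 to compound 2 (1.12 log units; beyond the scatter). Compound 4 differs from compound 3 by the same change, (pyrimidin-2-yl in place of phenyl on an amine nitrogen in a ring). Among the compounds with values here, only one example of this change is known here, and it sits on a much stronger core, so for compound 4 a somewhat smaller step is expected, a 7.9-fold lower number from compound 3 to compound 4 (0.90 log units; beyond the scatter). Compound 4 is therefore expected to give about 4000 nM in this assay. For compound 4 the expected range runs from 1000 nM to 20000 nM.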

Compound 4, half-maximal inhibitory concentration: 460 nM
Compound 4: middle estimate off by 8.7-fold (0.94 log units), on the high side; the whole stated range lies above it.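

On the core of compound 3, the same change gives a 69-fold lower number from compound 3 to compound 4 (1.84 log units; beyond the scatter) in this assay and so goes in the same direction as on the core of compound 1. The size of the step, however, does not carry over unchanged: the same change on two cores in this assay, a 13-fold lower number (1.12 log units; beyond the scatter) from compound 1 to compound 2 and a 69-fold lower number (1.84 log units; beyond the scatter) from compound 3 to compound 4, 5.2-fold (0.72 log units) apart, beyond the scatter of two such steps. Within the data shown here, with only two pairs, this shows that the direction held on both cores, but it gives no rule for predicting the size on another core and does not explain the gap.

The compounds shown carry only phenyl or pyrimidin-2-yl on this ring nitrogen, so it remains open how a pyridin-2-yl or a simple methyl group would compare. From the compounds shown here alone, it also remains open whether the change would behave the same way on a core with a longer chain.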